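This account rests on a few compounds, and the source may have more. Where it says the series, first, only, none or still open, it means among the compounds named here.

Three compounds have been measured in a functional assay on PC-12 cells (Rattus norvegicus) for cytotoxicity, read by MTT assay, with stated times of 2 h and 24 h, tested at 5 uM; on this read-out lower numbers stand for a weaker effect and higher numbers for a stronger effect at the one concentration tested:

Compound 1 `Oc1cc(C(F)(F)F)ccc1-c1nc(-c2ccccc2O)n(-c2ccc(I)cc2)n1` gives 94.4%.
Compound 2 `Oc1cc(C(F)(F)F)ccc1-c1nc(-c2ccccc2O)n(-c2ccccc2F)n1` gives 86.6%.
Compound 3 `Oc1cc(C(F)(F)F)ccc1-c1nc(-c2ccccc2O)n(-c2ccccc2Cl)n1` gives 90.6%.

Compound 1 carries the highest of the three numbers, yet neither gap separates it from the others: the step of a number 3.8 percentage points lower from compound 1 to compound 3 (within the scatter) and the step of a number 7.8 percentage points lower from compound 1 to compound 2 (within the scatter) both fall inside the scatter, as does the step of a number 4 percentage points higher from compound 2 to compound 3 (within the scatter). All three compounds therefore give numbers that cannot be told apart in this assay.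

Compound 4 `Cc1ccc(-n2nc(-c3ccc(C(F)(F)F)cc3O)nc2-c2ccccc2O)c(C)c1` has not yet been measured. It differs from compound 1 in one place: 2,4-dimethylphenyl in place of 4-iodophenyl on an aromatic nitrogen. The two measured steps that bear on this change are those from compound 1 to compound 2 and from compound 1 to compound 3, in which other aryl groups replace 4-iodophenyl on the same aromatic nitrogen; both stayed within the scatter. A third aryl replacement at that position is therefore expected to produce no step beyond the scatter either, so the estimated step of a number 4.4 percentage points lower from compound 1 to compound 4 (within the scatter) is small. Compound 4 is expected to give about 90% in this assay, estimated between 78% and 98%.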

Compound 4, a percentage reported as activity, at one concentration (the size of the read-out at that concentration, not a potency): 93.3%
Beside the measured number, compound 4's estimate is 3.3 percentage points below it; measured number inside the range.
By their numbers in this assay, from the lowest: compounds 2, 3, 4 and 1 (each within the scatter of the next).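

In this assay, going by these compounds alone, the earlier compounds carried only a halogen on the aryl group at this aromatic nitrogen, whereas compound 4 has two methyl groups and no halogen on it. Even so, the step of a number 1.1 percentage points lower from compound 1 to compound 4 (within the scatter) and the step of a number 2.7 percentage points higher from compound 3 to compound 4 (within the scatter) and the step of a number 6.7 percentage points higher from compound 2 to compound 4 (within the scatter) all lie inside the scatter, so among these four compounds a halogen on this aryl group is not needed for a number of this size. Nothing at hand speaks to what lies behind these numbers.

On these data alone, whether an aryl group bearing an amine or a carboxylic acid, or a longer alkyl chain in place of the aryl group, would also stay within the scatter remains open. The shared core is the same throughout, so a methoxy group in place of the hydroxyl of the 2-hydroxyphenyl group is also left open.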